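Trifluoromethoxy for methoxy on an aryl aminomethyl phthalimide

The compounds below may be only part of what the source reports. "The series", "measured", "known", "first", "only" and "open" are said of these compounds alone.

Measured so far:
compound 1, `CC(C)c1ccc(NCN2C(=O)c3ccccc3C2=O)cc1`, 46.5%;
compound 2, `COc1ccc(NCN2C(=O)c3ccccc3C2=O)cc1`, 97.2%.

Among the compounds with values here, in an assay on isolated protein for inhibition of ribosomal protein S6 kinase alpha-2 (Homo sapiens), read by fluorescence, with a stated time of 20 min, tested at 10 uM (on this read-out lower numbers stand for less inhibition and higher numbers for more inhibition at the one concentration tested (going by the name of the read-out)), compound 2 gives the higher of the two numbers recorded, and compound 1 sits well below it: the one step known, a number 50.7 percentage points higher from compound 1 to compound 2 (beyond the scatter), lies beyond the scatter. Compound 3, `O=C1c2ccccc2C(=O)N1CNc1ccc(OC(F)(F)F)cc1`, carries the change (trifluoromethyl in place of methyl on an oxygen on an aromatic ring). Within the data shown here, no measured step touches the oxygen substituent itself; the only step available concerns a different group on the same ring, so it bears on compound 3 only by showing that this ring position can swing the read-out widely. Because compound 2 already gives 97.2%, little room remains upward, and a move downward from it is the more open possibility. Compound 3 is therefore expected to give 78%, within 40% to 99%. The step that this estimate implies, a number 19.2 percentage points lower from compound 2 to compound 3 (beyond the scatter), is expected as a moderate fall that could still fall within the scatter.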

Compound 3, a percentage reported as inhibition, at one concentration (the size of the read-out at that concentration, not a potency): 28.1%
Estimate against measurement, compound 3: 49.9 percentage points above; the whole stated range lies above it.
By their numbers in this assay, from the lowest: compound 3; then compound 1; then compound 2.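

In this assay, the group on the oxygen turns out to matter in its own right: with the oxygen kept on the aromatic ring, trifluoromethyl in place of methyl gives a number 69.1 percentage points lower from compound 2 to compound 3 (beyond the scatter). The trifluoromethoxy group also falls short of the isopropyl group, with a number 18.4 percentage points lower from compound 1 to compound 3 (beyond the scatter), so of the three compounds only the methoxy compound reaches a high number, and an oxygen at this place does not secure one. Nothing available explains the fall, and no measurement bears on its cause.

The compounds shown leave open whether the high number is particular to methoxy or also holds for ethoxy, a hydroxyl or an amine at this place. With one concentration tested, they also leave open how these compounds compare in potency.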